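Trimming the Acyl Group on the Piperazine Amide

The compounds below may be only part of what the source reports. "The series", "measured", "known", "first", "only" and "open" are said of these compounds alone.

Compound 3 `Cc1cccc(Cn2c(CN3CCN(C(=O)CC(C)C)CC3)nc3ccccc32)c1` gives 71.4% in an assay on isolated protein for inhibition of aldehyde dehydrogenase 1A1 (Homo sapiens), read by spectrophotometry, tested at 10 uM (a higher number here means more inhibition at the concentration tested (going by the name of the read-out), a lower number less inhibition), the highest of the three numbers shown, though compound 2 `Cc1cccc(Cn2c(CN3CCN(C(=O)C4CCCC4)CC3)nc3ccccc32)c1` with 67.5% sits within the scatter of it, so neither can be ranked above the other. Compound 1 `Cc1cccc(Cn2c(CN3CCN(C(=O)c4cccnc4)CC3)nc3ccccc32)c1` gives 24.5%, and the step of a number 46.9 percentage points higher from compound 1 to compound 3 (beyond the scatter) is large. Compound 4 `CC(=O)N1CCN(Cc2nc3ccccc3n2Cc2cccc(C)c2)CC1` differs from compound 3 by hydrogen in place of isopropyl on a saturated chain carbon bound to a carbonyl carbon. The step of a number 3.9 percentage points higher from compound 2 to compound 3 (within the scatter) shows that exchanging one saturated acyl group for another changed little, whereas a number 46.9 percentage points higher from compound 1 to compound 3 (beyond the scatter) shows the acyl group can matter greatly. Removing the isopropyl leaves a much smaller acetyl, so a moderate decrease is expected, a number 23.4 percentage points lower from compound 3 to compound 4 (beyond the scatter). Compound 4 is estimated at 48%, within 25% to 72%.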

Compound 4, a percentage reported as inhibition, at one concentration (the size of the read-out at that concentration, not a potency): 70.3%
Compound 4: the middle estimate sits 22.3 percentage points below what was measured; low and high end bracket the measured number.
By their numbers in this assay, from the lowest: compound 1; then compounds 2, 4 and 3 (each within the scatter of the next).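

Shortening the acyl group to acetyl leaves the read-out in this assay in the same range as the larger saturated groups, with a number 1.1 percentage points lower from compound 3 to compound 4 (within the scatter) and a number 2.8 percentage points higher from compound 2 to compound 4 (within the scatter) for the exchange of cyclopentyl for methyl. Among these compounds the bulk of the saturated group therefore shows no effect at this position, and only the pyridin-3-yl stands apart, with a number 45.8 percentage points higher from compound 1 to compound 4 (beyond the scatter) on going to methyl. Nothing given here accounts for the gap between pyridin-3-yl and the saturated groups.

From the compounds shown here alone, whether a phenyl group on the carbonyl carbon would read like the pyridin-3-yl or like the saturated groups remains open. So does the effect of an amine or a carboxylic acid on the acyl chain.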